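From 4-chlorophenyl to phenyl: compound 2 to compound 3

This account rests on a few compounds, and the source may have more. Where it says the series, first, only, none or still open, it means among the compounds named here.

In a functional assay on HCT-116 cells (Homo sapiens) for antiproliferative activity, read by MTT assay, with a stated time of 72 h (a higher number here means a weaker inhibitor, a lower number a stronger inhibitor), compound 1 `COc1cccc(N2C(=O)COc3ccc(-c4cccc(NS(=O)(=O)c5ccc(F)cc5)c4)cc32)c1` gives > 40000 nM as a limit and not a number. Going by the values given here, compound 2 `O=C1COc2ccc(-c3cccc(NS(=O)(=O)c4ccc(F)cc4)c3)cc2N1c1ccc(Cl)cc1` stands at 23900 nM as the only actual number so far. Compound 3 `O=C1COc2ccc(-c3cccc(NS(=O)(=O)c4ccc(F)cc4)c3)cc2N1c1ccccc1` carries hydrogen in place of chloro on an aromatic carbon, para to a large group, with hydrogen in place of chloro on an aromatic carbon as the counted difference. Among the compounds with values here, the one measured step touching this phenyl group is an at least 1.6-fold lower number from compound 1 to compound 2 (0.22 log units; that floor lies within the scatter) and it sets no size to carry over. No step beyond the scatter is therefore expected in this assay, and the estimated step is a 1.3-fold higher number from compound 2 to compound 3 (0.10 log units; within the scatter) at most a slight weakening. For compound 3 the estimate is 30000 nM with 14000 nM to 60000 nM as the expected range.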

Compound 3, half-maximal inhibitory concentration: > 40000 nM
Compound 3: no number, only a limit (the forecaster's own chance of this, stated with the estimate: 40%); middle value at least 1.3-fold (0.12 log units) from the limit.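

In this assay, hydrogen in place of chloro on this aromatic carbon gives an at least 1.6-fold higher number from compound 2 to compound 3 (0.22 log units; that floor lies within the scatter), so the real size of the change remains hidden behind a floor. Among the three groups shown on the ring nitrogen, only 4-chlorophenyl gives an actual number, and the other two compounds yield only a limit: the limit of > 40000 nM in this assay, at which 2 of the 3 values shown sit. The step from compound 1 to compound 3 cannot be read, since both are limits.

Going by these compounds, how far compound 1 and compound 3 lie past that limit stays open. Also open, on these data alone, is what an amine or a carboxylic acid on this aromatic carbon would give.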